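Methoxy addition to the aryl end of compound 1

A few compounds are considered here, and "the series" means these few. Any claim that something is new, unique, unknown or untested is made for them only; others in the source may bear on it.

In a functional assay on THP-1 cells (Homo sapiens) for inhibition, read by sulforhodamine B assay, with a stated time of 48 h, tested at 50 uM (on this read-out lower numbers stand for less inhibition of growth and higher numbers for more inhibition of growth at the one concentration tested), compound 1 `COc1ccc(/C=C/C(=O)/C=C/c2ccc(OCc3cn(CCCCCOc4cc(=O)oc5ccccc45)nn3)c(OC)c2)cc1OC` gives 47%. Compound 2 `COc1ccccc1/C=C/C(=O)/C=C/c1ccc(OCc2cn(CCCCOc3cc(=O)oc4ccccc34)nn2)c(OC)c1` gives 40%, within the scatter of compound 1, so the two numbers do not separate. Compound 3 `COc1cc(/C=C/C(=O)/C=C/c2cc(OC)c(OC)c(OC)c2)ccc1OCc1cn(CCCCCOc2cc(=O)oc3ccccc23)nn1` differs from compound 1 by methoxy in place of hydrogen on an aromatic carbon, turning 3,4-dimethoxyphenyl into 3,4,5-trimethoxyphenyl. Among the measured compounds shown here, no measured pair shows this change alone, so no step beyond the scatter is expected in this assay. The expected step is a number 3 percentage points higher from compound 1 to compound 3 (within the scatter), slightly upward if anything. Compound 3 is estimated at 50%, with an expected range of 36% to 66%.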

Compound 3, percent growth inhibition at one concentration: 55%
For compound 3 the middle estimate is 5 percentage points below the measured one, within the range that was stated.
By their numbers in this assay, from the lowest: compounds 2, 1 and 3 (each within the scatter of the next, the first and the last beyond it).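

In this assay, among the compounds shown here, turning 3,4-dimethoxyphenyl into 3,4,5-trimethoxyphenyl gives a number 8 percentage points higher from compound 1 to compound 3 (within the scatter) as the first reading of this change alone. Methoxy in place of hydrogen on this aromatic carbon is therefore tolerated, but the two compounds do not separate. No measurement on hand bears on the reason for this result.

As far as these compounds go, whether an amine or a carboxylic acid on the same carbon would move the number beyond the scatter remains open. So does whether a step of this kind holds at other concentrations.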